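From 2,3-dichlorophenyl to 4-fluorophenyl: notes on growth inhibition

The source may report more compounds than this note shows. Statements on the series, on what has been measured and on what is new or still open speak of the compounds shown alone.

Of the compounds shown here, two on the shared core have been measured so far. In a functional assay on PC-3 cells (Homo sapiens) for inhibition, read by MTT assay, with a stated time of 48 h, tested at 10 uM (a higher number here means more inhibition of growth at the concentration tested, a lower number less inhibition of growth), compound 1 `CCOc1ccc(Br)c(C(O)c2c(C)oc3c([C@H]4CCN(C)C[C@H]4O)c(O)cc(O)c3c2=O)c1` gives 0% and compound 2 `Cc1oc2c([C@H]3CCN(C)C[C@H]3O)c(O)cc(O)c2c(=O)c1C(O)c1cccc(Cl)c1Cl` gives 20% as the higher of the two numbers.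

The next compound to be tested is compound 3 `Cc1oc2c([C@H]3CCN(C)C[C@H]3O)c(O)cc(O)c2c(=O)c1C(O)c1ccc(F)cc1` which carries 4-fluorophenyl in place of 2,3-dichlorophenyl on a saturated chain carbon bound to an aromatic carbon and an oxygen on a saturated carbon on a saturated chain carbon bound to an aromatic carbon and an oxygen on a saturated carbon.

Among the compounds with values here, one measured step bears on this change, since it replaces the group at the same place: a number 20 percentage points higher from compound 1 to compound 2 (beyond the scatter) with 2,3-dichlorophenyl in place of 2-bromo-5-ethoxyphenyl. That step is modest. Neither measured compound carries 4-fluorophenyl, and one step does not fix a direction for a different group.

The expected change is a number 5 percentage points lower from compound 2 to compound 3 (within the scatter) and no step beyond the scatter is expected. For compound 3 the estimated value in this assay is 15% with an expected range from 0% to 35% in this test.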

Compound 3, percent growth inhibition at one concentration: 0%
For compound 3 the middle estimate is 15 percentage points above the measured one; the range from low to high includes it.
By their numbers in this assay, from the lowest: compounds 1 and 3 (each within the scatter of the next); then compound 2.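

In this assay the place on a saturated chain carbon bound to an aromatic carbon and an oxygen on a saturated carbon now shows a loss as well as a gain: the result reads a number 20 percentage points lower from compound 2 to compound 3 (beyond the scatter) with 4-fluorophenyl in place of 2,3-dichlorophenyl, so compound 2 alone stands apart among the three compounds. The second comparison gives no change at the digits printed from compound 1 to compound 3 (within the scatter) with 4-fluorophenyl in place of 2-bromo-5-ethoxyphenyl, so this read-out does not separate these two groups, and the earlier gain is tied so far to 2,3-dichlorophenyl rather than to a change of aryl group in general. Nothing available explains why 2,3-dichlorophenyl stands apart from the other two groups.

The compounds shown leave open whether both chlorines of 2,3-dichlorophenyl are needed, which a 3-chlorophenyl or 2-chlorophenyl group at this place would begin to answer. They also leave open whether a ring carrying a nitrogen, such as pyridyl, or an amine on the phenyl ring would stay with compound 2 or fall with compound 1 and compound 3.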